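A few compounds are considered here, and "the series" means these few. Any claim that something is new, unique, unknown or untested is made for them only; others in the source may bear on it.

In a functional assay on DU-145 cells (Homo sapiens) for cytotoxicity, read by sulforhodamine B assay, with a stated time of 48 h (on this read-out lower numbers stand for stronger inhibition and higher numbers for weaker inhibition), three compounds have been measured so far:
compound 1 `COc1ccc(/C=C2\C(=O)N(Cc3cn([C@@H]4O[C@H](COC(C)=O)[C@@H](OC(C)=O)[C@H](OC(C)=O)[C@H]4OC(C)=O)nn3)c3ccccc32)cc1OC` gives 24900 nM;
compound 2 `CC(=O)OC[C@H]1O[C@@H](n2cc(CN3C(=O)/C(=C\C=C\c4ccccc4)c4ccccc43)nn2)[C@H](OC(C)=O)[C@@H](OC(C)=O)[C@@H]1OC(C)=O` gives 19500 nM;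
compound 3 `CC(=O)OC[C@H]1O[C@@H](n2cc(CN3C(=O)/C(=C\c4ccc5ccccc5c4)c4ccccc43)nn2)[C@H](OC(C)=O)[C@@H](OC(C)=O)[C@@H]1OC(C)=O` gives only a limit of the assay, > 100000 nM.

Compound 3 therefore stands at the weak end of what has been measured: among the three values it is the one sitting at the limit of > 100000 nM in this assay, at which 1 of the 3 values shown sits. What separates these compounds is the aromatic group on a double-bonded chain carbon bound to a double-bonded ring carbon. Going from the group of compound 1 to that of compound 2 changed little: a 1.3-fold lower number from compound 1 to compound 2 (0.11 log units; within the scatter). Putting naphthalen-2-yl in that place cost activity: an at least 4.0-fold higher number from compound 1 to compound 3 (0.60 log units; beyond the scatter), and an at least 5.1-fold higher number from compound 2 to compound 3 (0.70 log units; beyond the scatter).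

Compound 4 `CC(=O)OC[C@H]1O[C@@H](n2cc(CN3C(=O)/C(=C\c4ccco4)c4ccccc43)nn2)[C@H](OC(C)=O)[C@@H](OC(C)=O)[C@@H]1OC(C)=O` has not yet been measured in this assay. It differs from compound 3 in one place: furan-2-yl in place of naphthalen-2-yl on a double-bonded chain carbon bound to a double-bonded ring carbon. The two measured steps that bear on this place both went from a smaller aryl group to naphthalen-2-yl and both ran into the limit; the move to furan-2-yl reverses that direction, toward a smaller ring group. A step back to a measurable number is therefore expected, roughly of the size seen in the steps into compound 3, though the limit leaves the true size uncertain. For compound 4 the estimate is 30000 nM, within 10000 nM to 100000 nM, which corresponds to an expected at least 3.3-fold lower number from compound 3 to compound 4 (0.52 log units; beyond the scatter).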

Compound 4, half-maximal inhibitory concentration: 16900 nM
For compound 4 the middle estimate is 1.8-fold (0.25 log units) above the measured one, within the range that was stated.
By their numbers in this assay, from the lowest: compounds 4, 2 and 1 (each within the scatter of the next). At a limit, above all of these: compound 3.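

In this assay, furan-2-yl in place of naphthalen-2-yl on a double-bonded chain carbon bound to a double-bonded ring carbon brings back a measurable number, with an at least 5.9-fold lower number from compound 3 to compound 4 (0.77 log units; beyond the scatter). The new group, a single five-membered aromatic ring with 1 hetero atom, matches the two earlier groups within the scatter, with a 1.2-fold lower number from compound 2 to compound 4 (0.06 log units; within the scatter) and a 1.5-fold lower number from compound 1 to compound 4 (0.17 log units; within the scatter), so this place accepts three quite different groups with no readable change. Among the four groups shown, only naphthalen-2-yl, with its 2 six-membered aromatic rings of carbon only, leaves its compound, compound 3, at a limit of the assay rather than at a number: the limit of > 100000 nM in this assay, at which 1 of the 4 values shown sits.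

That limit leaves the true size of the step from compound 3 to compound 4 unknown, so how much naphthalen-2-yl costs cannot be stated exactly. As far as these compounds go, it also remains open whether an unsubstituted phenyl, a thiophen-2-yl or a pyridin-3-yl ring at this place would fall in with compound 1, compound 2 and compound 4, fall away like compound 3, or give a clearly lower number than any of them.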